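The compounds below may be only part of what the source reports. "The series", "measured", "known", "first", "only" and "open" are said of these compounds alone.

Working notes on the series. Compound 1 `O=C1C(=O)N(Cc2ccc(-c3ccccc3)cc2)c2ccc(OC(F)(F)F)cc21` is the reference point here; in a physicochemical assay for lipophilicity (on this read-out lower numbers stand for lower lipophilicity and higher numbers for higher lipophilicity), compound 1 gives 4.6. Compound 2 `O=C1C(=O)N(Cc2ccc(-c3cccnc3)nc2)c2ccc(OC(F)(F)F)cc21` carries two ring nitrogens in place of the carbon-only rings of compound 1, and in this assay compound 2 gives 3. Among the measured compounds shown here, of the two numbers measured so far, compound 2 stands lowest, and the gap to compound 1 is well beyond the usual scatter; no single-point step between the two measured compounds is available, so the two values are simply noted as they stand.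

The next compound, compound 3 `O=C1C(=O)N(Cc2ccc(-c3ccccc3)nc2)c2ccc(OC(F)(F)F)cc21`, differs from compound 2 in one place: phenyl in place of pyridin-3-yl on an aromatic carbon. For the measured compounds named here, no measured pair shows the effect of this change by itself. The change removes one of the two hydrogen-bond acceptors that separate compound 2 from compound 1, and the expectation is a rise in this assay that covers only part of the gap seen between compound 2 at 3 and compound 1 at 4.6. The estimated step from compound 2 to compound 3 is a number 0.80 log units higher from compound 2 to compound 3 (beyond the scatter), clearly beyond the scatter. Compound 3 is therefore expected to give about 3.8, within a range from 3.3 to 4.3.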

Compound 3, partition coefficient: 3.6
For compound 3 the middle estimate is 0.20 log units above the measured one, within the range that was stated.
By their numbers in this assay, from the lowest: compound 2; then compound 3; then compound 1.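

Working from this assay, the swap of pyridin-3-yl for phenyl on an aromatic carbon, next to the ring nitrogen and para to a large group, gives a number 0.60 log units higher from compound 2 to compound 3 (beyond the scatter) as the first single-place step in the series. The two groups match at 6 heavy atoms with no net charge, and they differ in that pyridin-3-yl has 1 hetero atom and 1 hydrogen-bond acceptor, while phenyl has 0 hydrogen-bond acceptors, so the step belongs to that one exchange of a ring nitrogen for carbon. Compound 3 at 3.6 still stands under compound 1 at 4.6, so this swap alone does not bring the series up to the value of compound 1, and no measurement at hand accounts for the size of the step.

Open, on these data alone, is whether a morpholine, a carboxylic acid or a short alkyl chain in place of phenyl at this position would move the read-out further in either direction. Also open, as far as these compounds go, is whether the same swap gives a step of similar size on a core that lacks the ring nitrogen of compound 3.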